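A few compounds are considered here, and "the series" means these few. Any claim that something is new, unique, unknown or untested is made for them only; others in the source may bear on it.

Compound 1 `CCCCCCCCN1C(=O)CCc2cc(-n3cnnc3)ccc21` and compound 2 `O=C1CCc2cc(-n3cnnc3)ccc2N1Cc1ccccc1F` share a core and differ only in the group on the saturated chain carbon bound to the amide-type nitrogen in the ring. In a functional assay on the whole organism (strain KunMing) with Mus musculus as the target, in the maximal electroshock model, with a stated time of 4 h (a higher number here means that more compound is needed for the effect, a lower number that less compound is needed), compound 1 gives 300 mg/kg, and in this assay compound 2 gives 300 mg/kg. The step of no change at the digits printed from compound 1 to compound 2 (within the scatter) covers the exchange of heptyl for 2-fluorophenyl. Compound 2 thus stands level with compound 1 at the digits shown, with no nearer neighbour. Compound 3 `O=C1CCc2cc(-n3cnnc3)ccc2N1Cc1ccccc1Cl` carries chloro in place of fluoro on an aromatic carbon. Among the measured compounds shown here, no measured step bears directly on this change; the single step that exists, heptyl to 2-fluorophenyl, showed nothing beyond the scatter. One therefore expects, as no change at the digits printed from compound 2 to compound 3 (within the scatter) states, no step beyond the scatter in this assay. Compound 3 is estimated in this assay at 300 mg/kg, with a range from 150 mg/kg to 600 mg/kg.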

Compound 3, minimum effective dose: 300 mg/kg
Compound 3: the middle estimate sits on the measured number at the digits printed; the measured number falls inside the stated range.
By their numbers in this assay, from the lowest: compounds 1, 2 and 3 (each within the scatter of the next).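

In this assay, among the compounds shown here, the exchange of fluoro for chloro on this aromatic carbon, ortho to a large group, gives no change at the digits printed from compound 2 to compound 3 (within the scatter) and is the first reading of a change on the aromatic ring itself. The wider exchange of heptyl for 2-chlorophenyl gives no change at the digits printed from compound 1 to compound 3 (within the scatter) and so adds a second aromatic group that stands level with the chain in this read-out. Nothing on hand accounts for the three compounds sharing one value.

The compounds shown leave open whether bromo, methoxy or a nitrile on this aromatic carbon would separate from fluoro and chloro in this assay. They also leave open whether an unsubstituted benzyl group or an amine-bearing chain on the same saturated chain carbon would depart from this shared level.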